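The source may report more compounds than this note shows. Statements on the series, on what has been measured and on what is new or still open speak of the compounds shown alone.

Measured compounds:

Compound 1 `NS(=O)(=O)NCCC1CCN(c2cc(-c3ccccc3)ncn2)CC1` gives in a functional assay on M21 cells (Homo sapiens) for antiproliferative activity, read by sulforhodamine B assay, with a stated time of 48 h (a lower number here means a stronger inhibitor of growth, a higher number a weaker inhibitor of growth), a value that is a limit of the assay, > 100000 nM.

Compound 2 `NS(=O)(=O)NCCC1CCN(c2cc(-c3ccccc3Cl)ncn2)CC1` gives in this assay 93900 nM.

Where compound 2 stands: its value is the only number shown in this assay; the one further value is a limit. The step of an at least 1.0-fold lower number from compound 1 to compound 2 (0.02 log units; that floor lies within the scatter), chloro in place of hydrogen on an aromatic carbon, runs from the limit of > 100000 nM in this assay, at which 1 of the 2 values shown sits, and has a floor that lies within the scatter, so it gives no direction.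

Compound 3 `NS(=O)(=O)NCCC1CCN(c2cc(-c3ccccc3F)ncn2)CC1` differs from compound 2 by fluoro in place of chloro on an aromatic carbon. Among the compounds with values here, the only measured step that bears on this change is the one from compound 1 to compound 2, and it carries no direction. No step beyond the scatter is therefore expected in this assay, a 1.1-fold higher number from compound 2 to compound 3 (0.03 log units; within the scatter), though with little data the range is wide and a limit may be reported. Compound 3 is estimated at 100000 nM, between 30000 nM and 300000 nM.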

Compound 3, concentration for 50% growth inhibition: 81800 nM
Estimate against measurement, compound 3: 1.2-fold (0.09 log units) above; the range from low to high includes it.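

With two numbers now available at this position, the change from 2-chlorophenyl to 2-fluorophenyl can be read directly in this assay: a 1.1-fold lower number from compound 2 to compound 3 (0.06 log units; within the scatter), so the two halogens cannot be told apart here. Fluoro in place of hydrogen reads an at least 1.2-fold lower number from compound 1 to compound 3 (0.08 log units; that floor lies within the scatter), which gives no direction, so no gain from fluoro over hydrogen is shown. Compound 1 holds a limit and not a number: the limit of > 100000 nM in this assay, at which 1 of the 3 values shown sits.

As far as these compounds go, whether any group at this position can move growth inhibition beyond the scatter stays open, for example a methoxy, an amine or a carboxylic acid in place of the halogen. Equally open, from the compounds shown here alone, is whether a change away from this position, such as a longer chain on the shared core, would move the number at all.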